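A few compounds are considered here, and "the series" means these few. Any claim that something is new, unique, unknown or untested is made for them only; others in the source may bear on it.

Measured so far:
compound 1, `c1cc(-c2ccn[nH]2)c2c(c1)C(c1ncc[nH]1)CC2`: 52 nM
compound 2, `Cc1c(OCC2=NCCN2)ccc(Cl)c1NS(C)(=O)=O`: 25 nM
compound 3, `CCS(=O)(=O)Nc1cccc(Cc2c[nH]cn2)c1`: 9 nM

These three compounds were tested in a functional assay on CHO cells for agonist activity at Alpha-1A adrenergic receptor (Homo sapiens), read by FLIPR and calcium flux; a lower number here means that less compound is needed, a higher number that more compound is needed for the effect. Compound 1 gives the highest number of the three. Compound 2 sits nearest to it, with a number that is lower by a gap beyond the scatter, and compound 3 is furthest away, with a number lower by a clearly larger gap. Compound 4, `CS(=O)(=O)Nc1cccc2c1CCC2c1ncc[nH]1`, has not yet been measured. It comes from compound 1 by one change: methanesulfonamido in place of 1H-pyrazol-5-yl on an aromatic carbon, on an aromatic carbon of a six-membered aromatic ring of carbon only, part of a fused system of two rings, ortho to a fused ring and meta to a fused ring. Among the compounds with values here, no measured pair isolates this change, so the expected step rests on the company compound 4 keeps: compound 3, which carries a sulfonamide, gives 9 nM, and compound 2, also a sulfonamide, gives 25 nM. A moderate step toward a lower number from compound 1 to compound 4 is therefore expected, a 2.6-fold lower number from compound 1 to compound 4 (0.41 log units; beyond the scatter). Compound 4 is estimated at 20 nM, with a range from 5 nM to 80 nM.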

Compound 4, half-maximal effective concentration: 70 nM
For compound 4 the middle estimate is 3.5-fold (0.54 log units) below the measured one, within the range that was stated.
By their numbers in this assay, from the lowest: compound 3; then compound 2; then compounds 1 and 4 (each within the scatter of the next).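

In this assay, placing methanesulfonamido instead of 1H-pyrazol-5-yl on this aromatic carbon, ortho to a fused ring and meta to a fused ring, gives a 1.3-fold higher number from compound 1 to compound 4 (0.13 log units; within the scatter) and so leaves the two compounds indistinguishable in this assay. This pair shows that a five-membered aromatic ring and a group with no ring can be exchanged at this position with no step beyond the scatter, and that methanesulfonamido on this core does not by itself give a lower number. No measurement available here explains why the two groups read alike.

On these data alone, whether a plain amine, a carboxylic acid or a methoxy group at this position would give a step beyond the scatter remains open. So does whether methanesulfonamido would read the same on another aromatic carbon of this ring.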